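Fluoro for Hydrogen Repeated on a Second Core

This account rests on a few compounds, and the source may have more. Where it says the series, first, only, none or still open, it means among the compounds named here.

Compound 1, `COc1ccc(-c2cc(C(C)=O)c3[nH]c(-c4ccccc4)cc3c2)cc1`, in a functional assay on MCF7 cells (Homo sapiens) for cytotoxicity, read by MTT assay, with a stated time of 2 days, tested at 100 uM (on this read-out lower numbers stand for a stronger effect and higher numbers for a weaker effect at the one concentration tested), gives 30.8%.
Compound 2, `COc1ccc(-c2cc(C(C)=O)c3[nH]c(-c4ccc(F)cc4)cc3c2)cc1`, in this assay gives 14.8%.
Compound 3, `CC(=O)c1cc(/C=C/c2ccccc2)cc2cc(-c3ccccc3)[nH]c12`, in this assay gives 34.1%.

Of the compounds shown here, three have been measured, and a fourth, compound 4, `CC(=O)c1cc(/C=C/c2ccccc2)cc2cc(-c3ccc(F)cc3)[nH]c12`, has not. Compounds 1 and 3 share most of their structure; the difference between the two cores is 2-phenylethenyl in place of 4-methoxyphenyl on an aromatic carbon. In this assay this leads to a number 3.3 percentage points higher from compound 1 to compound 3 (within the scatter), so the two cores cannot be told apart on this read-out.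

Within the core of compound 1, one change has been measured: fluoro in place of hydrogen on an aromatic carbon. In this assay it gives a number 16 percentage points lower from compound 1 to compound 2 (beyond the scatter), a shift toward a stronger effect that lies beyond the usual scatter.

Compound 4 stands to compound 3 exactly as compound 2 stands to compound 1: fluoro in place of hydrogen on an aromatic carbon. The place of the change is described in the same words in both pairs, so this is the same change carried onto a core that, by the step from compound 1 to compound 3, behaves alike on this read-out. For the measured compounds named here, the account therefore expects a number 16.1 percentage points lower from compound 3 to compound 4 (beyond the scatter), a step of about the size seen from compound 1 to compound 2, because a number 16 percentage points lower from compound 1 to compound 2 (beyond the scatter) is the only measured instance of this change and nothing among the three compounds speaks against carrying it over. On that basis compound 4 is estimated to give 18% in this assay, with the expected range running from 6% to 32%.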

Compound 4, a percentage reported as activity, at one concentration (the size of the read-out at that concentration, not a potency): 50.1%
The estimate for compound 4 lay 32.1 percentage points below the measured number; measured number outside the range, above it.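

In this assay, fluoro in place of hydrogen on an aromatic carbon did not carry over from one core to the other: on the second core it gives a number 16 percentage points higher from compound 3 to compound 4 (beyond the scatter), a shift toward a weaker effect, and the two instances of the change differ: the same change on two cores in this assay, a number 16 percentage points lower (beyond the scatter) from compound 1 to compound 2 and a number 16 percentage points higher (beyond the scatter) from compound 3 to compound 4, 32 percentage points apart, beyond the scatter of two such steps Read the other way, the exchange of 4-methoxyphenyl for 2-phenylethenyl, which could not be seen without the fluoro, gives a number 35.3 percentage points higher from compound 2 to compound 4 (beyond the scatter) once the fluoro is present: the same change on two cores in this assay, a number 3.3 percentage points higher (within the scatter) from compound 1 to compound 3 and a number 35.3 percentage points higher (beyond the scatter) from compound 2 to compound 4, 32 percentage points apart, beyond the scatter of two such steps This shows that, among these four compounds, the step for this change depends on the core it is made on, so a step measured on one core cannot simply be transferred to the other; it does not show why the two cores part, and each core offers only a single pair, read at one concentration.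

The compounds shown leave open whether chloro or an amine in place of the fluoro would split between the two cores in the same way. They also leave open how the change would behave with a longer chain or a carboxylic acid in place of 2-phenylethenyl or 4-methoxyphenyl, and whether the split would persist at a lower concentration.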